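The source may report more compounds than this note shows. Statements on the series, on what has been measured and on what is new or still open speak of the compounds shown alone.

Three close analogues share one core and differ only in the aryl group carried on the ring nitrogen. In a functional assay on A-431 cells (Homo sapiens) for antiproliferative activity, read by MTT assay, with a stated time of 72 h (a higher number here means a weaker inhibitor, a lower number a stronger inhibitor), compound 1 `C#Cc1cccc(Nc2ncnc3cc(OC)c(OCCCCC(=O)Nc4ccc(S(N)(=O)=O)cc4)cc23)c1` gives 17700 nM. Compound 2 `COc1cc2ncnc(Nc3cccc(Cl)c3)c2cc1OCCCCC(=O)Nc1ccc(S(N)(=O)=O)cc1` gives 30400 nM in this assay, and compound 3 `COc1ccc(Nc2ncnc3cc(OC)c(OCCCCC(=O)Nc4ccc(S(N)(=O)=O)cc4)cc23)cc1` gives 14700 nM. The number for compound 1 lies within the scatter of both neighbours: a 1.7-fold higher number from compound 1 to compound 2 (0.23 log units; within the scatter) and a 1.2-fold lower number from compound 1 to compound 3 (0.08 log units; within the scatter), so nothing separates compound 1 from either on these data. Within the data shown here, only the step of a 2.1-fold lower number from compound 2 to compound 3 (0.32 log units; beyond the scatter) reaches beyond the scatter, and modestly.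

Compound 4 `COc1cc2ncnc(Nc3cccc(Cl)c3F)c2cc1OCCCCC(=O)Nc1ccc(S(N)(=O)=O)cc1` is compound 1 with 3-chloro-2-fluorophenyl in place of 3-ethynylphenyl on a nitrogen on an aromatic ring. Among the measured compounds shown here, the closest measured step is the exchange of ethynyl for chloro, a 1.7-fold higher number from compound 1 to compound 2 (0.23 log units; within the scatter), which stayed within the scatter; the added fluorine has no measured counterpart here. Compound 4 is therefore expected to land close to compound 1 in this assay, a 1.2-fold higher number from compound 1 to compound 4 (0.09 log units; within the scatter), with no step beyond the scatter foreseen. The estimate for compound 4 is 22000 nM, expected to fall between 9000 nM and 55000 nM.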

Compound 4, half-maximal inhibitory concentration: 5560 nM
The estimate for compound 4 lay 4.0-fold (0.60 log units) above the measured number, and the stated range ends above it.
By their numbers in this assay, from the lowest: compound 4; then compounds 3, 1 and 2 (each within the scatter of the next, the first and the last beyond it).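

In this assay, the group on the nitrogen matters more than the first three compounds suggested: adding a single fluoro to the 3-chlorophenyl group gives a 5.5-fold lower number from compound 2 to compound 4 (0.74 log units; beyond the scatter), the largest step seen in this set. Replacing the whole aryl group with 3-chloro-2-fluorophenyl also goes beyond the scatter, giving a 3.2-fold lower number from compound 1 to compound 4 (0.50 log units; beyond the scatter) and a 2.6-fold lower number from compound 3 to compound 4 (0.42 log units; beyond the scatter), so compound 4 is the strongest inhibitor of the four. Nothing available explains why this small change has such an effect.

The compounds shown leave open whether the fluoro needs the chloro to produce this gain, which a 2-fluorophenyl group on the same nitrogen would test. From the compounds shown here alone, it is also open whether a bromo in place of the chloro in compound 4 would keep the number this low.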